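The compounds below may be only part of what the source reports. "The series", "measured", "known", "first", "only" and "open" are said of these compounds alone.

Going by the values given here, compound 3, `CCn1c(=O)c2nc(-c3ccc(S(=O)(=O)NCCN(C)C)cc3)[nH]c2n(CC)c1=O`, is one of three compounds measured in an assay for binding affinity to adenosine receptor A1 (Bos taurus) (on this read-out higher numbers stand for weaker inhibition and lower numbers for stronger inhibition), where compound 3 gives 3.3 nM. Compound 2, `CCn1c(=O)c2nc(-c3ccc(S(=O)(=O)NCCCN(C)C)cc3)[nH]c2n(CC)c1=O`, gives 1.6 nM, and compound 1, `CCn1c(=O)c2nc(-c3ccc(S(=O)(=O)N4CCSCC4)cc3)[nH]c2n(CC)c1=O`, gives 36.6 nM. Compound 3 therefore stands second of the three: a 2.1-fold higher number from compound 2 to compound 3 (0.31 log units; beyond the scatter), while the other way an 11-fold lower number from compound 1 to compound 3 (1.04 log units; beyond the scatter). Compound 4, `CCn1c(=O)c2nc(-c3ccc(S(=O)(=O)NCC(C)O)cc3)[nH]c2n(CC)c1=O`, has not yet been measured. It differs from compound 3 in one place: 1-hydroxyethyl in place of (dimethylamino)methyl on a saturated chain carbon bound to a sulfonamide nitrogen. Among the compounds with values here, two measured steps touch the group on the sulfonyl sulfur, a 23-fold lower number from compound 1 to compound 2 (1.36 log units; beyond the scatter) and an 11-fold lower number from compound 1 to compound 3 (1.04 log units; beyond the scatter), both large, and both move from thiomorpholin-4-yl to a chain carrying dimethylamino. The change to compound 4 removes that dimethylamino and brings in 1-hydroxyethyl, while keeping the sulfonamide nitrogen as a donor. Within the data shown here, no measured pair tests this swap directly, so the expectation is uncertain and leans on how much the dimethylamino-bearing chains gained over compound 1. A step of a 3.6-fold higher number from compound 3 to compound 4 (0.56 log units; beyond the scatter) toward a higher number is expected. Compound 4 is therefore estimated at 12 nM, within a range from 4 nM to 40 nM.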

Compound 4, half-maximal inhibitory concentration: 4.2 nM
Estimate against measurement, compound 4: 2.9-fold (0.46 log units) above; the range from low to high includes it.
By their numbers in this assay, from the lowest: compound 2; then compounds 3 and 4 (each within the scatter of the next); then compound 1.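

In this assay the dimethylamino group proves not to be needed at this position: the measured difference is a 1.3-fold higher number from compound 3 to compound 4 (0.10 log units; within the scatter) and so 1-hydroxyethyl on a saturated chain carbon bound to a sulfonamide nitrogen does as well as (dimethylamino)methyl. Most of the gain over thiomorpholin-4-yl also remains without that amine, with an 8.7-fold lower number from compound 1 to compound 4 (0.94 log units; beyond the scatter) on the sulfonyl sulfur, while a 2.6-fold higher number from compound 2 to compound 4 (0.42 log units; beyond the scatter) keeps compound 2 lowest of the four. Nothing shown here explains why these different chains give such close numbers. Still open, going by these compounds, is whether the hydroxyl itself matters at all, since a plain propyl chain on the sulfonamide nitrogen would separate its share from that of the carbon chain. A carboxylic acid at the chain end, or a longer 3-hydroxypropyl chain, would show how much else this position accepts.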